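The source may hold more compounds than are shown below. What is called first, only, known or untested is meant among the compounds shown, and "the series" means these compounds.

Measured so far in an ADME assay on S9 fraction from liver (Homo sapiens) for metabolic stability, with a stated time of 1 h; on this read-out higher numbers stand for a more stable compound and lower numbers for a less stable compound:
- Compound 1 `N#Cc1cnc(NCc2cnccc2C(F)(F)F)cc1N[C@H]1C[C@@H](O)C1` gives 90%
- Compound 2 `N#Cc1cnc(NCc2cnccc2C(F)(F)F)cc1N[C@H]1C[C@H](O)C1` gives 96%
- Compound 3 `N#Cc1cnc(NCc2cnccc2C(F)(F)F)cc1NC[C@H]1CC[C@@H](O)CC1` gives 41%

Compound 3 stands lowest of the three in this assay, and its gaps to the other two are large. The steps are a number 49 percentage points lower from compound 1 to compound 3 (beyond the scatter) and a number 55 percentage points lower from compound 2 to compound 3 (beyond the scatter), and both are the same exchange: (4-hydroxycyclohexyl)methyl in place of 3-hydroxycyclobutyl on a nitrogen on an aromatic ring. The remaining step, a number 6 percentage points higher from compound 1 to compound 2 (within the scatter), involves (the fact that compounds 1 and 2 differ only in the configuration as drawn), so it says little about the next change.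

That change leads to compound 4 `N#Cc1cnc(NCc2cnccc2C(F)(F)F)cc1NC1CCOCC1`, and it is counted as oxan-4-yl in place of (4-hydroxycyclohexyl)methyl on a nitrogen on an aromatic ring. Here (4-hydroxycyclohexyl)methyl leaves, the group found only in compound 3, the one low compound. Among the compounds with values here, no measured compound carries oxan-4-yl, so the two large steps offer only indirect guidance. They suggest that compound 4 may move back towards compound 1 at 90%, but the new group adds real uncertainty. The expected change is a number 37 percentage points higher from compound 3 to compound 4 (beyond the scatter), a rise beyond the scatter. The estimated value for compound 4 is 78%, with an expected range from 52% to 97%.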

Compound 4, percent of the compound remaining: 91%
Beside the measured number, compound 4's estimate is 13 percentage points below it, within the range that was stated.
By their numbers in this assay, from the lowest: compound 3; then compounds 1, 4 and 2 (each within the scatter of the next).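

In this assay, the exchange of (4-hydroxycyclohexyl)methyl for oxan-4-yl on a nitrogen on an aromatic ring undoes the low number of compound 3: a number 50 percentage points higher from compound 3 to compound 4 (beyond the scatter). This shows that a six-membered non-aromatic ring at this position does not by itself go with a low number, since compound 4 also carries one, though with an oxygen in the ring and without the extra carbon link to the nitrogen. Oxan-4-yl also stands level with 3-hydroxycyclobutyl, as a number 5 percentage points lower from compound 2 to compound 4 (within the scatter) and a number 1 percentage points higher from compound 1 to compound 4 (within the scatter), so a hydroxyl group is not needed for a high number here, and compound 3 remains the only low compound.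

Compound 3 and compound 4 differ in several features at once, so a group such as (oxan-4-yl)methyl or 4-hydroxycyclohexyl, each changing only part of that difference, would be needed to tell which feature goes with the drop. The data shown give no reason for the low number of compound 3 or for the recovery in compound 4.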